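The source may hold more compounds than are shown below. What is called first, only, known or untested is meant among the compounds shown, and "the series" means these compounds.

Measured in an ADME assay on HepG2 2.2.15 cells (Homo sapiens) for cytotoxicity; a higher number here means that more compound is tolerated, a lower number that less compound is tolerated:

- compound 1 `O=C(CCC1CCCCC1)OCCc1c(-c2ccccc2Cl)c2cc(Cl)ccc2[nH]c1=O` gives 160000 nM
- compound 2 `O=C(OCCc1c(-c2ccccc2Cl)c2cc(Cl)ccc2[nH]c1=O)c1cccs1` gives > 1700000 nM (a limit)
- compound 3 `COc1ccc(/C=C/C(=O)OCCc2c(-c3ccccc3Cl)c3cc(Cl)ccc3[nH]c2=O)cc1` gives > 1200000 nM (a limit)

Compound 3 therefore has no exact number in this assay, and its position is known only as a limit. Compound 2 is also known only as a limit. Compound 1 is the only one of the three with an exact value.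

The next compound is compound 4 `C/C=C/C=C/C(=O)OCCc1c(-c2ccccc2Cl)c2cc(Cl)ccc2[nH]c1=O`. The change is prop-1-en-1-yl in place of 4-methoxyphenyl on a double-bonded chain carbon bound to a double-bonded chain carbon, with prop-1-en-1-yl in place of 4-methoxyphenyl on a double-bonded chain carbon bound to a double-bonded chain carbon. Cut one bond further out, 2-(4-methoxyphenyl)ethenyl gives way to penta-1,3-dien-1-yl.

Among the compounds with values here, no measured step makes this exact change, so the evidence is indirect. The data show an at least 7.5-fold higher number from compound 1 to compound 3 (0.87 log units; beyond the scatter), and this step is beyond the scatter. They also show an at least 10-fold higher number from compound 1 to compound 2 (1.02 log units; beyond the scatter), again beyond the scatter. In both, the 2-cyclohexylethyl group is what leaves. The remaining comparison gives a step that the two limits leave unreadable from compound 2 to compound 3, so it sets no size.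

Compound 4 keeps the ethenyl link of compound 3, so no step beyond the scatter is expected. The expected step is an at least 1.2-fold lower number from compound 3 to compound 4 (0.07 log units; that floor lies within the scatter), and a limit is again a likely result. The estimated value for compound 4 is 1000000 nM, with an expected range from 250000 nM to 2500000 nM.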

Compound 4, half-maximal cytotoxic concentration: 440000 nM
Compound 4: the middle estimate sits 2.3-fold (0.36 log units) above what was measured; measured number inside the range.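

In this assay, the change on a double-bonded chain carbon bound to a double-bonded chain carbon is not a silent one: with the ethenyl link kept, prop-1-en-1-yl in place of 4-methoxyphenyl gives an at least 2.7-fold lower number from compound 3 to compound 4 (0.43 log units; beyond the scatter). Compound 4 also falls short of the thiophen-2-yl ester, with an at least 3.8-fold lower number from compound 2 to compound 4 (0.58 log units; beyond the scatter), yet it still stands clear of the 2-cyclohexylethyl ester, with a 2.8-fold higher number from compound 1 to compound 4 (0.44 log units; beyond the scatter), so the group on the carbonyl carbon now yields an exact value in the middle of the series rather than only a limit. The drop from compound 3 can be read only as a minimum, because compound 3 is known only as a limit: the limit of > 1200000 nM in this assay, at which 1 of the 4 values shown sits.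

The true distance from compound 2 to compound 4 stays open, because compound 2 is also known only as a limit: the limit of > 1700000 nM in this assay, at which 1 of the 4 values shown sits. The compounds shown also leave open whether the drop follows the loss of the 4-methoxyphenyl ring or the added double bond of penta-1,3-dien-1-yl, and where an unsubstituted phenyl, a saturated pentyl chain or a chain ending in an amine would fall.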